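Carbamate series: propargyl to benzyl on the ring amine

The source may report more compounds than this note shows. Statements on the series, on what has been measured and on what is new or still open speak of the compounds shown alone.

Measured so far in an assay on BTI-TN-5B1-4 cells for inhibition of Amine oxidase [flavin-containing] A (Homo sapiens), read by fluorescence and Amplex Red, using microsomes, with a stated time of 15 min; on this read-out higher numbers stand for weaker inhibition and lower numbers for stronger inhibition:
compound 1 `C#CCN1CCCC(OC(=O)Nc2ccccc2)C1`: > 100000 nM
compound 2 `O=C(Nc1ccccc1)OC1CCCN(Cc2ccccc2)C1`: > 100000 nM
compound 3 `C#CCN1CCC(OC(=O)Nc2ccc(C(C)C)cc2)CC1`: > 100000 nM

The value for compound 1 is a limit of this assay, not a number. The value for compound 2 is likewise a limit. The value for compound 3 is a limit as well. Compound 2 arises from compound 1 by phenyl in place of ethynyl on a saturated chain carbon bound to an amine nitrogen in a ring; the step that the two limits leave unreadable from compound 1 to compound 2 cannot be sized because the limit of > 100000 nM in this assay, at which 3 of the 3 values shown sit, holds for both ends. The difference between the cores of compound 1 and compound 3 is not broken down here. Compound 4 `CC(C)c1ccc(NC(=O)OC2CCN(Cc3ccccc3)CC2)cc1` differs from compound 3 by phenyl in place of ethynyl on a saturated chain carbon bound to an amine nitrogen in a ring, the same change. The step from compound 3 to compound 4 is expected to be a step that the limit leaves unreadable from compound 3 to compound 4, resting on the limit of > 100000 nM in this assay, at which 3 of the 3 values shown sit, and on the unreadable step from compound 1 to compound 2. Compound 4 is therefore estimated at 150000 nM in this assay, most likely again reported only as a limit.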

Compound 4, half-maximal inhibitory concentration: > 100000 nM
Compound 4: only a limit was reported; the forecaster's own chance of this, stated with the estimate: 85%; the middle value is on the limit's open side.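

No step can be read from compound 3 to compound 4, as both are reported only as limits: the limit of > 100000 nM in this assay, at which 4 of the 4 values shown sit.

The compounds shown leave open whether propargyl and benzyl on the ring amine differ at all in inhibiting this enzyme.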